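The source may report more compounds than this note shows. Statements on the series, on what has been measured and on what is new or still open speak of the compounds shown alone.

In a functional assay on SMMC-7721 cells (Homo sapiens) for inhibition, read by CCK-8 assay, with a stated time of 72 h (on this read-out lower numbers stand for stronger inhibition and higher numbers for weaker inhibition), compound 1 (`Nc1ccccc1NC(=O)c1ccc(CNC(=O)c2n[nH]cc2NC(=O)c2ccccc2)cc1`) gives 6620 nM, compound 2 (`Nc1ccccc1NC(=O)c1ccc(CNC(=O)c2n[nH]cc2NC(=O)c2c(Cl)cccc2Cl)cc1`) gives 7760 nM and compound 3 (`Nc1ccccc1NC(=O)c1ccc(CNC(=O)c2n[nH]cc2NC(=O)c2ccccc2F)cc1`) gives 6850 nM. Compound 3 therefore stands among three values that lie within the scatter of one another. Compound 4 (`Nc1ccccc1NC(=O)c1ccc(CNC(=O)c2n[nH]cc2NC(=O)c2c(F)cccc2F)cc1`) differs from compound 3 by fluoro in place of hydrogen on an aromatic carbon, with fluoro in place of hydrogen on an aromatic carbon, turning 2-fluorophenyl into 2,6-difluorophenyl. For the measured compounds named here, the closest precedent is the same kind of replacement, a 1.0-fold higher number from compound 1 to compound 3 (0.01 log units; within the scatter). The other two measured steps, a 1.2-fold higher number from compound 1 to compound 2 (0.07 log units; within the scatter) and a 1.1-fold lower number from compound 2 to compound 3 (0.05 log units; within the scatter), also change this aryl group, and all three stay within the scatter. No step beyond the scatter is therefore expected in this assay, and the estimated step is a 1.0-fold higher number from compound 3 to compound 4 (0.00 log units; within the scatter). Compound 4 is expected at 6900 nM, within an estimated range of 4500 nM to 10500 nM.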

Compound 4, half-maximal inhibitory concentration: 15200 nM
Estimate against measurement, compound 4: 2.2-fold (0.34 log units) below; the whole stated range lies below it.
By their numbers in this assay, from the lowest: compounds 1, 3, 2 and 4 (each within the scatter of the next, the first and the last beyond it).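

In this assay, for the compounds shown here, the second fluoro, turning 2-fluorophenyl into 2,6-difluorophenyl, is the first change to this aryl group that goes beyond the scatter (a 2.2-fold higher number from compound 3 to compound 4 (0.35 log units; beyond the scatter)), and the comparison with plain phenyl agrees (a 2.3-fold higher number from compound 1 to compound 4 (0.36 log units; beyond the scatter)). The step from 2,6-dichlorophenyl stays within the scatter (a 2.0-fold higher number from compound 2 to compound 4 (0.29 log units; within the scatter)), and that group itself lay within the scatter of phenyl, so the shift is modest and is not shared by both 2,6-disubstituted compounds. Nothing given here bears on why this fluoro changes the number.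

From the compounds shown here alone, whether a methyl, a methoxy or an amine in this place would behave like fluoro stays open. So does whether the change carries over to other cell lines.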